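Ester size and cytotoxicity in a trisubstituted anilino series

The source may report more compounds than this note shows. Statements on the series, on what has been measured and on what is new or still open speak of the compounds shown alone.

Measured compounds:
- compound 1, `CCOC(=O)c1sc2ccccc2c1Nc1cc(OC)c(OC)c(OC)c1`: 1900 nM
- compound 2, `COC(=O)c1sc2ncccc2c1Nc1cc(OC)c(OC)c(OC)c1`: 348 nM
- compound 3, `COC(=O)c1sc2ccccc2c1Nc1cc(OC)c(OC)c(OC)c1`: 179 nM

All three were tested in a functional assay on SEM cells (Homo sapiens) for cytotoxicity, read by MTT assay, with a stated time of 72 h; on this read-out lower numbers stand for stronger inhibition and higher numbers for weaker inhibition. Compound 3 and compound 1 differ in one place: methyl in place of hydrogen on a saturated chain carbon bound to an oxygen next to a carbonyl group. That single change gave an 11-fold higher number from compound 3 to compound 1 (1.03 log units; beyond the scatter), a clear weakening. The cores of compound 2 and compound 3 differ as well, but the difference between the two cores is not broken down here; the two values show that compound 2 and compound 3 sit within the usual scatter of each other, so no order between them is claimed.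

Compound 4, `CCOC(=O)c1sc2ncccc2c1Nc1cc(OC)c(OC)c(OC)c1`, has not yet been measured. It stands to compound 2 as compound 1 stands to compound 3: methyl in place of hydrogen on a saturated chain carbon bound to an oxygen next to a carbonyl group. Because the same kind of change on the core of compound 3 gave an 11-fold higher number from compound 3 to compound 1 (1.03 log units; beyond the scatter), a step of about an 8.6-fold higher number from compound 2 to compound 4 (0.94 log units; beyond the scatter) is expected in this assay, though it rests on a single earlier example. For compound 4 a value near 3000 nM is therefore estimated, with a plausible span from 900 nM to 10000 nM.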

Compound 4, half-maximal inhibitory concentration: 1850 nM
For compound 4 the middle estimate is 1.6-fold (0.21 log units) above the measured one; the range from low to high includes it.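

On a second core, the change from methoxycarbonyl to ethoxycarbonyl gave a 5.3-fold higher number from compound 2 to compound 4 (0.73 log units; beyond the scatter) in this assay, so the added methyl weakened the result here too. The two steps agree in direction, and their sizes cannot be told apart: the same change on two cores in this assay, an 11-fold higher number (1.03 log units; beyond the scatter) from compound 3 to compound 1 and a 5.3-fold higher number (0.73 log units; beyond the scatter) from compound 2 to compound 4, 2.0-fold (0.30 log units) apart, within the scatter of two such steps. This shows that, for these two cores, the step measured on one core was a fair guide to the step on the other, but two pairs of compounds establish no general rule for the series, and they do not explain why the longer ester gives the higher number.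

The compounds shown cover only the methoxycarbonyl and ethoxycarbonyl groups, so it remains open how a longer chain such as a propyl ester, or an amide or a carboxylic acid in the same place, would behave in this cytotoxicity test. From the compounds shown here alone, it also remains open whether the step would hold on any core beyond these two.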